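This account rests on a few compounds, and the source may have more. Where it says the series, first, only, none or still open, it means among the compounds named here.

Compound 3 is `Cc1ccc(S(=O)(=O)NCCCNc2nccc(-c3c(-c4cccc(F)c4)nc4sccn34)n2)cc1`. Among the measured compounds shown here, in a functional assay on A-375 cells (Homo sapiens) for cytotoxicity, read by MTT assay (a lower number here means a stronger inhibitor, a higher number a weaker inhibitor), compound 3 gives 8380 nM, which places it second highest of the three numbers so far. Its nearest neighbour is compound 2, `O=S(=O)(NCCCNc1nccc(-c2c(-c3cccc(F)c3)nc3sccn23)n1)c1ccc(Cl)cc1`, and compound 2 gives 5900 nM; the step of a 1.4-fold higher number from compound 2 to compound 3 (0.15 log units; within the scatter) lies within the scatter. Furthest from it is compound 1, `O=S(=O)(NCCCNc1nccc(-c2c(-c3cccc(F)c3)nc3sccn23)n1)c1ccc(F)cc1`, and compound 1 gives 14500 nM; the step of a 1.7-fold lower number from compound 1 to compound 3 (0.24 log units; within the scatter) is also within the scatter, while the step of a 2.5-fold lower number from compound 1 to compound 2 (0.39 log units; beyond the scatter) is the only one beyond it.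

Compound 4 is `O=C(NCCCNc1nccc(-c2c(-c3cccc(F)c3)nc3sccn23)n1)c1ccc(F)cc1`. Its difference from compound 3 is (4-fluorophenyl)carbonyl in place of (4-methylphenyl)sulfonyl on an amine nitrogen. Two things change at once: the group on the aromatic ring and the linking group on the amine nitrogen. For the measured compounds named here, of these, only the first has any precedent in the measured compounds, where swapping methyl for fluoro on the aromatic carbon, a 1.7-fold lower number from compound 1 to compound 3 (0.24 log units; within the scatter), stayed within the scatter. Going by the values given here, the exchange of a sulfonyl for a carbonyl on the amine nitrogen has no measured counterpart here, so no step size can be read from the data for it. On that basis compound 4 is expected to sit close to compound 3, with wide uncertainty, so that the expected step of a 1.2-fold higher number from compound 3 to compound 4 (0.08 log units; within the scatter) is not beyond the scatter. The estimated value for compound 4 in this assay is 10000 nM, within a range from 3000 nM to 35000 nM.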

Compound 4, half-maximal inhibitory concentration: 14900 nM
For compound 4 the middle estimate is 1.5-fold (0.17 log units) below the measured one; low and high end bracket the measured number.
By their numbers in this assay, from the lowest: compounds 2, 3, 1 and 4 (each within the scatter of the next, the first and the last beyond it).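

Among the compounds shown here, with the (4-fluorophenyl) group kept, exchanging the sulfonyl for a carbonyl on the amine nitrogen gives the first direct reading of that linking group in this assay: a 1.0-fold higher number from compound 1 to compound 4 (0.01 log units; within the scatter), so this single exchange does not separate the two compounds beyond the scatter. The other two steps to the new amide differ in size, with a 1.8-fold higher number from compound 3 to compound 4 (0.25 log units; within the scatter) also staying within the scatter, while a 2.5-fold higher number from compound 2 to compound 4 (0.40 log units; beyond the scatter) goes beyond it, though only modestly, and this gap matches the one already seen for the fluoro-to-chloro change in the sulfonyl compounds, so compound 2 remains the one that stands apart from the fluorophenyl pair. No measurement shown here accounts for these numbers.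

From the compounds shown here alone, what remains open is whether the chloro gain seen among the sulfonyl compounds would carry over to (4-chlorophenyl)carbonyl on the same amine nitrogen, since the carbonyl link is represented by a single aryl group here. Going by these compounds, it is also open how this assay would respond to a urea or a plain methylene in place of the sulfonyl or carbonyl, or to a longer chain on that nitrogen.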